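Cyclohexyl for ethyl on a furan-bearing acrylate ester

A few compounds are considered here, and "the series" means these few. Any claim that something is new, unique, unknown or untested is made for them only; others in the source may bear on it.

Measured compounds:
Compound 1, `N#C/C(=C\c1ccc[nH]1)C(=O)OC1CCCCC1`: 10%
Compound 2, `CCOC(=O)/C(C#N)=C/c1ccoc1`: 55.9%

Both compounds were tested in a functional assay on the whole organism (strain CD1) for inhibition, with Mus musculus as the target, with stated times of 15 min and 20 min, at a dose of 10 mg/kg by the subcutaneous route; a higher number here means more inhibition at the dose given (going by the name of the read-out), a lower number less inhibition. Compound 2 stands highest of the two numbers; compound 1 lies a gap below it that exceeds the usual scatter. The two differ in more than one place, so their values alone say nothing about either change on its own.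

Compound 3, `N#C/C(=C\c1ccoc1)C(=O)OC1CCCCC1`, has not yet been measured. It differs from compound 2 in one place: cyclohexyl in place of ethyl on an oxygen next to a carbonyl group. Among the measured compounds shown here, no measured pair isolates this change, so its effect is uncertain. The low value of compound 1, which also carries a cyclohexyl on that oxygen, is the only hint, and it is confounded by the other ring. Compound 3 is therefore expected to give 40%, within 15% to 65%. This estimate means an expected step of a number 15.9 percentage points lower from compound 2 to compound 3 (beyond the scatter), a decrease at the edge of the scatter.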

Compound 3, a percentage reported as inhibition, in the whole organism at one dose (the size of the read-out at that dose, not a potency): 91.2%
Beside the measured number, compound 3's estimate is 51.2 percentage points below it; measured number outside the range, above it.
By their numbers in this assay, from the lowest: compound 1; then compound 2; then compound 3.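

In this assay, cyclohexyl in place of ethyl on an oxygen next to a carbonyl group gives a number 35.3 percentage points higher from compound 2 to compound 3 (beyond the scatter) and so shows that, with furan-3-yl in the molecule, this position takes the larger ring with a gain in inhibition rather than a loss. With cyclohexyl held the same, furan-3-yl in place of 1H-pyrrol-2-yl on a double-bonded chain carbon bound to a double-bonded chain carbon gives a number 81.2 percentage points higher from compound 1 to compound 3 (beyond the scatter) and so ties the low value of compound 1 to that ring change, not to the cyclohexyl. Nothing at hand explains either step.

Going by these compounds, whether the gain would hold with 1H-pyrrol-2-yl in the molecule remains open. So does how the position would respond to a phenyl ring or a longer chain such as n-butyl on the same oxygen.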